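This account rests on a few compounds, and the source may have more. Where it says the series, first, only, none or still open, it means among the compounds named here.

The measured compounds and their results in a functional assay on HeLa cells (Homo sapiens) for antiproliferative activity, read by MTT assay, with a stated time of 48 h (a higher number here means a weaker inhibitor, a lower number a stronger inhibitor), are these: compound 1 `Cc1ccc(C(=O)Nc2ccc(Cl)cc2C(N)=O)cc1` gives 8.23 ug/mL; compound 2 `Cc1ccc(-c2nc(N)c3cc(Cl)ccc3n2)cc1` gives 3.56 ug/mL; compound 3 `Cc1ccc(-c2nc(NN)c3cc(Cl)ccc3n2)cc1` gives 3.98 ug/mL.

Compound 3 holds the second highest of the three numbers in this assay. Its nearest neighbour is compound 2, and the step of a 1.1-fold higher number from compound 2 to compound 3 (0.05 log units; within the scatter) stays within the scatter, so the two cannot be ordered. Its furthest neighbour is compound 1, whose value lies beyond the scatter from that of compound 3, with compound 1 showing the higher number of the two.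

Compound 4 `Cc1ccc(-c2nc(NOC(=O)c3ccccc3)c3cc(Cl)ccc3n2)cc1` differs from compound 3 in one place: benzoyloxy in place of amino on a nitrogen on an aromatic ring. Among the compounds with values here, only one measured step touches the same nitrogen, the step of a 1.1-fold higher number from compound 2 to compound 3 (0.05 log units; within the scatter), and it was within the scatter. Within the data shown here, that step swapped a hydrogen for a small amino group; the present change brings in a far larger group, and no measured pair shows what such a group does on this nitrogen. On the evidence of the small earlier step, the estimated step of a 1.4-fold higher number from compound 3 to compound 4 (0.14 log units; within the scatter) is a modest move toward a higher number, not clearly beyond the scatter. Compound 4 is therefore expected to give about 5.5 ug/mL in this assay, with a likely range from 2.2 ug/mL to 14 ug/mL.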

Compound 4, half-maximal inhibitory concentration: 5.18 ug/mL
For compound 4 the middle estimate is 1.1-fold (0.03 log units) above the measured one; measured number inside the range.
By their numbers in this assay, from the lowest: compounds 2, 3, 4 and 1 (each within the scatter of the next, the first and the last beyond it).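

In this assay, the benzoyloxy group puts nine heavy atoms and a six-membered aromatic ring on the nitrogen, and the outcome is a 1.3-fold higher number from compound 3 to compound 4 (0.11 log units; within the scatter) and, against the unsubstituted amine, a 1.5-fold higher number from compound 2 to compound 4 (0.16 log units; within the scatter). Within the data shown here, the earlier compounds showed only a single small amino group at this position, whereas these values show that even this far larger group, joined through its oxygen, gives no reading beyond the scatter, so compound 2, compound 3 and compound 4 cannot be ordered. No evidence is at hand on why the values stay so close.

On these data alone, it remains open whether any group on this nitrogen, such as a longer alkyl chain, an acetyl group or a carboxylic acid, would move the number beyond the scatter. Also open, as far as these compounds go, is how a morpholine in place of the substituted nitrogen would read.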